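A few compounds are considered here, and "the series" means these few. Any claim that something is new, unique, unknown or untested is made for them only; others in the source may bear on it.

Compound 3 `CC[C@H](C)[C@H](N)CN(C(=O)[C@@H]1C[C@H]1c1ccccc1)c1ccc(-c2ccc(OC(C)C)cc2)cc1` has been measured in a functional assay for agonist activity at G protein-coupled receptor 88 (Homo sapiens), read by HTRF and cAMP accumulation (a higher number here means that more compound is needed for the effect, a lower number that less compound is needed), where compound 3 gives 72 nM. Among the single numbers in this assay, compound 3 gives the highest one; its nearest neighbour is compound 2 `CCCc1ccc(-c2ccc(N(C[C@@H](N)[C@@H](C)CC)C(=O)[C@@H]3C[C@H]3c3ccccc3)cc2)cc1`, which gives 61 nM, and the step of a 1.2-fold higher number from compound 2 to compound 3 (0.07 log units; within the scatter) lies within the scatter. Compound 1 `CC[C@H](C)[C@H](N)CN(C(=O)[C@@H]1C[C@H]1c1ccccc1)c1ccc(-c2ccccc2)cc1` has two entries in this assay rather than a single number: compound 1 gives 230 nM; 800 nM (2 entries), as recorded in the several entries of compound 1 in this assay, 230 nM; 800 nM (2 entries). Compound 4 `CC[C@H](C)[C@H](N)CN(C(=O)[C@@H]1C[C@H]1c1ccccc1)c1ccc(-c2ccc(Oc3ccccc3)cc2)cc1` differs from compound 3 in one place: phenyl in place of isopropyl on an oxygen on an aromatic ring. Among the measured compounds shown here, the only measured step that touches this part of the structure is the step from compound 2 to compound 3, and it stayed within the scatter, so no measured step speaks for a large change at this position. Compound 4 is therefore expected to show a step of a 1.4-fold higher number from compound 3 to compound 4 (0.14 log units; within the scatter) that stays close to the scatter, without a clear direction. For compound 4 the estimate is 100 nM, with a range from 30 nM to 400 nM.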

Compound 4, half-maximal effective concentration: 94 nM
For compound 4 the middle estimate is 1.1-fold (0.03 log units) above the measured one; low and high end bracket the measured number.
By their numbers in this assay, from the lowest: compounds 2, 3 and 4 (each within the scatter of the next).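

In this assay, among the compounds shown here, replacing isopropyl with phenyl on the oxygen gives a 1.3-fold higher number from compound 3 to compound 4 (0.12 log units; within the scatter), so a ring at this place leaves the number without a readable change, which the earlier compounds, none of which carries a ring here, could not show. Phenoxy also gives a 1.5-fold higher number from compound 2 to compound 4 (0.19 log units; within the scatter), so propyl, isopropoxy and phenoxy cannot be told apart at this place, even though they differ in size and in the presence of the oxygen or a ring. The comparison with compound 1, which has no group at this place, cannot be read as a single step, because its entries give no single number: the several entries of compound 1 in this assay, 230 nM; 800 nM (2 entries)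

As far as these compounds go, whether a group carrying an amine or a carboxylic acid at this place would move the number beyond the scatter remains open. So does the effect of a fluorine or a methoxy group on the entering phenyl ring.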